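The compounds below may be only part of what the source reports. "The series", "measured", "known", "first", "only" and "open" are said of these compounds alone.

In a functional assay on SK-BR-3 cells (Homo sapiens) for inhibition, read by CellTiter-Glo, with a stated time of 72 h (a lower number here means a stronger inhibitor, a higher number a weaker inhibitor), compound 1 (`CC(C)c1nn(-c2ccc(C(N)=O)c(N[C@H]3CC[C@H](O)CC3)c2)c2nccc(-n3cnc(-c4ccncc4)c3)c12`) gives 165 nM and compound 2 (`CC(C)c1nn(-c2ccc(C(N)=O)c(N[C@H]3CC[C@H](O)CC3)c2)c2ccnc(-c3cnc4ccccc4c3)c12`) gives 1720 nM as its value. Compound 1 therefore holds the lower of the two numbers, and the gap lies beyond the usual scatter. Compound 3 (`CC(C)c1nn(-c2ccc(C(N)=O)c(N[C@H]3CC[C@H](O)CC3)c2)c2nccc(-c3ccsc3)c12`) keeps the core of compound 1 but carries thiophen-3-yl in place of 4-(pyridin-4-yl)-1H-imidazol-1-yl on an aromatic carbon . Going by the values given here, no measured pair isolates this change, so the guidance is thin. Compound 2 also lacks the 4-(pyridin-4-yl)-1H-imidazol-1-yl group, and its value of 1720 nM leans the expectation toward a higher number. A modest weakening, a little beyond the scatter, is expected in this assay, with an estimated step of a 2.4-fold higher number from compound 1 to compound 3 (0.38 log units; beyond the scatter). For compound 3 the estimated value is 400 nM, with an expected range from 100 nM to 1600 nM.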

Compound 3, half-maximal inhibitory concentration: > 10000 nM
Compound 3: only a limit was reported; the forecaster's own chance of this, stated with the estimate: 5%; middle value at least 25-fold (1.39 log units) from the limit.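

On this aromatic carbon, opposite the ring nitrogen, the substituent matters greatly: in this assay, replacing 4-(pyridin-4-yl)-1H-imidazol-1-yl with thiophen-3-yl gives an at least 60-fold higher number from compound 1 to compound 3 (1.78 log units; beyond the scatter). Going by these compounds alone, this is the only step here between compounds that differ in one place, and it removes a group of two aromatic rings and puts one aromatic ring in its place. Compound 3 is recorded only as a limit, so the step gives a minimum size and no exact one: the limit of > 10000 nM in this assay, at which 1 of the 3 values shown sits.

Going by these compounds, the two rings of the departing group leave together, so the share of each in the loss stays open. A plain 1H-imidazol-1-yl group or a lone pyridin-4-yl group on this carbon would separate them.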